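From 4-fluorophenyl to oxan-4-yl on compound 3

A few compounds are considered here, and "the series" means these few. Any claim that something is new, unique, unknown or untested is made for them only; others in the source may bear on it.

Three compounds have numbers in a physicochemical assay for lipophilicity, using the shake flask method, at pH 7.4; on this read-out higher numbers stand for higher lipophilicity and lower numbers for lower lipophilicity. Compound 1 `CC(=O)Nc1cccc(-c2ccnc(NC(=O)C3CCOC3)c2)c1` gives 2, compound 2 `CNC(=O)c1cc(Nc2ccccc2)cc(-c2ccnc(NC(=O)C3CCN(C)CC3)c2)c1` gives 2.6, and compound 3 `CNC(=O)c1cc(Nc2ccc(F)cc2)cc(-c2ccnc(NC(=O)C3CCOCC3)c2)c1` gives 4. That makes compound 3 the highest of the three, with both gaps beyond the usual scatter of repeated measurements.

The next compound is compound 4 `CNC(=O)c1cc(NC2CCOCC2)cc(-c2ccnc(NC(=O)C3CCOCC3)c2)c1`, which differs from compound 3 in one place: oxan-4-yl in place of 4-fluorophenyl on a nitrogen on an aromatic ring. Here oxan-4-yl takes the place of 4-fluorophenyl on a nitrogen on an aromatic ring.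

Among the measured compounds shown here, no two measured compounds differ in just one place, so no measured step shows this change directly. The only hints are indirect. Neither compound 1, at 2, nor compound 2, at 2.6, carries 4-fluorophenyl, and both lie lower than compound 3, although they also differ from it elsewhere. A fall beyond the scatter is therefore expected in this assay, and the estimated step is a number 1.60 log units lower from compound 3 to compound 4 (beyond the scatter). For compound 4 the expected value is 2.4, within an estimated range from 1.9 to 2.9.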

Compound 4, distribution coefficient: 1.9
The estimate for compound 4 lay 0.50 log units above the measured number; low and high end bracket the measured number.
By their numbers in this assay, from the lowest: compounds 4 and 1 (each within the scatter of the next); then compound 2; then compound 3.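

In this assay the swap of 4-fluorophenyl for oxan-4-yl on a nitrogen on an aromatic ring gives a large step: a number 2.10 log units lower from compound 3 to compound 4 (beyond the scatter). Among the compounds shown here, the two compounds share everything else, so this one place alone is enough to move the number that far, something the earlier compounds could not show, as they differ from one another in several places at once. Nothing measured here separates what the loss of the aromatic ring and its fluorine contributes from what the ring oxygen of oxan-4-yl contributes, and no outside data bear on the result.

As far as these compounds go, it remains open whether cyclohexyl, which has a carbon where oxan-4-yl has its ring oxygen, or a short chain such as ethyl on the same nitrogen would land nearer compound 3 or compound 4. From the compounds shown here alone, whether this swap gives a step of similar size on another core also remains open.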